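Moving the pyridine nitrogen: from compound 2 to compound 3

The source may report more compounds than this note shows. Statements on the series, on what has been measured and on what is new or still open speak of the compounds shown alone.

Compound 1, `O=S(=O)(Nc1ccc(-c2cccnc2)c2cccnc12)c1cccc(C(F)(F)F)c1`, gives 3900 nM in a functional assay on NCI-H1299 cells (Homo sapiens) for antiproliferative activity, with a stated time of 2 days; a lower number here means a stronger inhibitor, a higher number a weaker inhibitor.
Compound 2, `O=S(=O)(Nc1ccc(-c2cccnc2)c2cccnc12)c1cccnc1`, gives 1050 nM in this assay.

Going by the values given here, compound 2 has the lower of the two numbers; the only other compound is compound 1, and the step of a 3.7-fold lower number from compound 1 to compound 2 (0.57 log units; beyond the scatter) changed the group on the sulfonyl sulfur. Compound 3, `O=S(=O)(Nc1ccc(-c2ccncc2)c2cccnc12)c1cccnc1`, differs from compound 2 elsewhere: pyridin-4-yl in place of pyridin-3-yl on an aromatic carbon. Among the compounds with values here, no measured step touches this part of the shared core, so the expected change is a 1.1-fold higher number from compound 2 to compound 3 (0.06 log units; within the scatter), within the scatter. Compound 3 is therefore expected to give about 1200 nM in this assay, ranging from 400 nM to 3600 nM.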

Compound 3, half-maximal inhibitory concentration: 9480 nM
For compound 3 the middle estimate is 7.9-fold (0.90 log units) below the measured one; measured number outside the range, above it.
By their numbers in this assay, from the lowest: compound 2; then compound 1; then compound 3.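

With the atoms unchanged and only their joining different, pyridin-4-yl in place of pyridin-3-yl gives a 9.0-fold higher number from compound 2 to compound 3 (0.96 log units; beyond the scatter). This aromatic carbon of the shared core is therefore sensitive to where the nitrogen sits in the attached pyridine ring, a point the change on the sulfonyl sulfur could not show. No available evidence explains this difference.

From the compounds shown here alone, whether a pyridin-2-yl group, a plain phenyl ring or an amine at this carbon would give a lower number than compound 2 remains open. So does whether the same nitrogen shift has a similar effect with 3-(trifluoromethyl)phenyl on the sulfonyl sulfur.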